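1,3-Thiazol-4-yl in place of 1,2-thiazol-5-yl

This account rests on a few compounds, and the source may have more. Where it says the series, first, only, none or still open, it means among the compounds named here.

Compound 1 `CC(=O)Oc1ccc(-n2cccc2)cc1C(=O)O` gives 42 mg/kg
Compound 2 `O=C(O)c1cc(-c2ccns2)ccc1O` gives 80 mg/kg
Compound 3 `O=C(O)c1cc(-c2ccncn2)ccc1O` gives > 200 mg/kg as a limit

In a functional assay on the whole organism for inhibition, with Rattus norvegicus as the target, read by paw edema (on this read-out lower numbers stand for an effect already at smaller amounts and higher numbers for an effect only at larger amounts of compound), compound 2 gives 80 mg/kg and lies within the usual scatter of compound 1 at 42 mg/kg on this scale. For compound 3 the result is only a limit, > 200 mg/kg and not a number. Compound 4 `O=C(O)c1cc(-c2cscn2)ccc1O` differs from compound 2 in one place (1,3-thiazol-4-yl in place of 1,2-thiazol-5-yl on an aromatic carbon), with 1,3-thiazol-4-yl in place of 1,2-thiazol-5-yl on an aromatic carbon, meta to a carboxy group and para to a hydroxy group. Going by the values given here, no measured step with a single change is available, so the expectation starts from compound 2 with its 80 mg/kg as the reference. A step of a 1.1-fold higher number from compound 2 to compound 4 (0.05 log units; within the scatter) is expected to stay within the scatter. For compound 4 the estimated value is 90 mg/kg with an expected range from 35 mg/kg to 200 mg/kg around it.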

Compound 4, dose for half-maximal effect: 95 mg/kg
The estimate for compound 4 lay 1.1-fold (0.02 log units) below the measured number; the measured number falls inside the stated range.
By their numbers in this assay, from the lowest: compounds 1, 2 and 4 (each within the scatter of the next, the first and the last beyond it). At a limit, above all of these: compound 3.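

Going by these compounds alone, the first single-change comparison in this assay gives a 1.2-fold higher number from compound 2 to compound 4 (0.07 log units; within the scatter). On an aromatic carbon, meta to a carboxy group and para to a hydroxy group, 1,2-thiazol-5-yl and 1,3-thiazol-4-yl, which hold the same atoms joined differently, therefore cannot be told apart on this read-out. Compound 3 stays a limit and not a number: the limit of > 200 mg/kg in this assay, at which 1 of the 4 values shown sits.

Open, going by these compounds, is how this position would respond to a group other than an aromatic ring, such as an amine or a longer chain.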